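The compounds below may be only part of what the source reports. "The series", "measured", "known", "first", "only" and "open" are said of these compounds alone.

Compound 2 `O=C(Nc1cc(F)c(F)c(F)c1)N1Cc2c(-c3ccc(F)cc3F)cnn2CC1C1CC1` gives, in a toxicity assay on HepG2 2.2.15 cells (Homo sapiens) for cytotoxicity, read by CellTiter-Glo (on this read-out higher numbers stand for lower toxicity in this test and lower numbers for higher toxicity in this test), a half-maximal cytotoxic concentration of 32100 nM, the lowest of the two numbers shown. Compound 1 `CC1CN(C(=O)Nc2cc(F)c(F)c(F)c2)Cc2c(N3CC(C#N)CC3=O)cnn21` gives 115000 nM in this assay, a higher number lying beyond the usual scatter. Compound 3 `C[C@H]1Cn2ncc(N3CC(c4ccccc4)CC3=O)c2CN1S(=O)(=O)Nc1cc(F)c(F)c(F)c1` is reported in this assay only as a limit, > 2000 nM, not as a number; this is the limit of > 2000 nM in this assay, at which 1 of the 3 values shown sits. Compound 4 `Cc1cnc(C2CC(=O)N(c3cnn4c3CN(C(=O)Nc3cc(F)c(F)c(F)c3)C(C3CC3)C4)C2)s1` differs from compound 2 by 4-(5-methyl-1,3-thiazol-2-yl)-2-oxopyrrolidin-1-yl in place of 2,4-difluorophenyl on an aromatic carbon. Among the measured compounds shown here, no step between two measured compounds matches this change, so only an expectation can be given: a moderate step upward, toward lower toxicity, is expected from compound 2 to compound 4, a 1.9-fold higher number from compound 2 to compound 4 (0.27 log units; within the scatter). Compound 4 is therefore estimated to give 60000 nM in this assay, expected between 20000 nM and 150000 nM.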

Compound 4, half-maximal cytotoxic concentration: 96200 nM
The estimate for compound 4 lay 1.6-fold (0.21 log units) below the measured number, within the range that was stated.
By their numbers in this assay, from the lowest: compound 2; then compounds 4 and 1 (each within the scatter of the next).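

Putting 4-(5-methyl-1,3-thiazol-2-yl)-2-oxopyrrolidin-1-yl in place of 2,4-difluorophenyl on this aromatic carbon gives a 3.0-fold higher number from compound 2 to compound 4 (0.48 log units; beyond the scatter) in this assay, a move toward lower toxicity in this test. Among the compounds shown here, this is the first comparison of compounds that differ in one place, so it is the first direct reading of a change at this position. The data shown do not tell what lies behind this step.

Going by these compounds, this one step swaps the whole group, so the separate shares of the oxopyrrolidine ring and the thiazole remain open. On these data alone, how an amine or a carboxylic acid on this carbon would compare also remains open.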